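Trimming a Furan Side Chain from a Bicyclic Terpenoid Scaffold

The source may report more compounds than this note shows. Statements on the series, on what has been measured and on what is new or still open speak of the compounds shown alone.

Measured compounds:
- compound 1 `CC1(C)CCC[C@]2(C)[C@@H](/C=C/c3ccoc3)C(C=O)=C(O)C(=O)[C@@H]12`: 23400 nM
- compound 2 `C=C1CC[C@H]2C(C)(C)CCC[C@]2(C)[C@H]1/C=C/c1ccoc1`: 34000 nM

In a functional assay on THP-1 cells (Homo sapiens) for cytotoxicity, read by MTT assay (on this read-out lower numbers stand for stronger inhibition and higher numbers for weaker inhibition), compound 1 gives 23400 nM and compound 2 gives 34000 nM. Compound 2 has the highest of the two numbers, but its gap to compound 1 lies within the scatter, so the two cannot be told apart on these data.

Compound 3 `C=C1CC[C@H]2C(C)(C)CCC[C@]2(C)[C@H]1C` has not yet been measured. It differs from compound 2 in one place: methyl in place of 2-(furan-3-yl)ethenyl on a saturated ring carbon. With the furan-bearing chain gone, compound 3 is a much smaller molecule than compound 2, and compound 2 itself already sits at the weak end of what has been measured. For the measured compounds named here, no step between measured compounds shows what this change does, so the expectation rests on the weak starting point alone: compound 3 is expected to show a step of a 1.8-fold higher number from compound 2 to compound 3 (0.25 log units; within the scatter) in this assay, toward weaker inhibition, about the size of the scatter or somewhat beyond it. Compound 3 is therefore estimated at 60000 nM in this assay, within a range of 25000 nM to 150000 nM.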

Compound 3, half-maximal inhibitory concentration: 53900 nM
Compound 3: middle estimate off by 1.1-fold (0.05 log units), on the high side; low and high end bracket the measured number.
By their numbers in this assay, from the lowest: compounds 1, 2 and 3 (each within the scatter of the next, the first and the last beyond it).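

In this assay, methyl in place of 2-(furan-3-yl)ethenyl on this saturated ring carbon gives a 1.6-fold higher number from compound 2 to compound 3 (0.20 log units; within the scatter) and so leaves compound 2 and compound 3 indistinguishable. For the compounds shown here, this is the first direct look at this position: the whole furan-bearing chain, with its five-membered aromatic ring and its double bond, can be replaced by a single carbon without a step beyond the scatter, so these data do not show that the chain matters for this read-out. Nothing on hand offers a reason for this result.

Going by these compounds, whether an ethyl group, or a chain ending in an amine or a carboxylic acid, on this ring carbon would give a step beyond the scatter remains open. Also open, on these data alone, is whether the same swap to methyl on the core of compound 1 would give a similar result.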